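A few compounds are considered here, and "the series" means these few. Any claim that something is new, unique, unknown or untested is made for them only; others in the source may bear on it.

Measured so far in dogs:

compound 1 `Cc1nc2c(OCc3ccccc3)ccc(C)n2c1C`: 13%
compound 2 `Cc1nc2c(OCc3ccccc3)cccn2c1NC=O`: 3%
compound 3 `Cc1nc2c(OCc3ccccc3)cccn2c1NC(=O)OCc1ccccc1`: 82%

All three numbers come from a functional assay on the whole organism with Canis familiaris (Canis lupus familiaris) as the target, at a dose of 2 mg/kg by the intravenous route; a higher number here means a stronger effect of the compound at the dose given, a lower number a weaker effect. Compound 2 holds the lowest of the three numbers, with compound 1 within the scatter of it and compound 3 far above it. Among the measured compounds shown here, the one step between compounds that differ in a single place is a number 79 percentage points higher from compound 2 to compound 3 (beyond the scatter), a large rise. Compound 4 `Cc1nc2c(OCc3ccccc3)cccn2c1/N=C/N(C)C` differs from compound 2 by a group of 5 heavy atoms (3 carbon, 2 nitrogen; no ring) in place of a group of 3 heavy atoms (1 carbon, 1 nitrogen, 1 oxygen; no ring), on an aromatic carbon. For the measured compounds named here, no measured step tests this exact change; the step from compound 2 to compound 3 shows only that the group on this aromatic carbon can matter greatly. Without a direct guide, a modest rise is expected: a number 12 percentage points higher from compound 2 to compound 4 (beyond the scatter). Compound 4 is estimated to give 15%, between 0% and 45%.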

Compound 4, a percentage reported as inhibition, in the whole organism at one dose (the size of the read-out at that dose, not a potency): 12%
Compound 4: middle estimate off by 3 percentage points, on the high side; the measured number falls inside the stated range.
By their numbers in this assay, from the lowest: compounds 2, 4 and 1 (each within the scatter of the next); then compound 3.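

In this assay, replacing formylamino with the larger group that has no hydrogen-bond donor gives a number 9 percentage points higher from compound 2 to compound 4 (within the scatter), whereas the step with the benzyloxy group gives a number 79 percentage points higher from compound 2 to compound 3 (beyond the scatter). So a new group on this aromatic carbon does not always shift the number, and having or lacking that donor does not by itself separate compound 2 from compound 4. Nothing measured here explains why these two compounds lie so close. The compounds shown leave open how a free amine or an acetylamino group would read at this position. They also leave open which part of the benzyloxy-bearing group of compound 3 goes with its high number.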